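Swapping the fluorophenyl for a pyridyl on compound 1

The compounds below may be only part of what the source reports. "The series", "measured", "known", "first", "only" and "open" are said of these compounds alone.

Among the measured compounds shown here, the three compounds measured so far share a core and differ at two places, one on the carbonyl and one at the end of the styryl-type chain. In an assay on isolated protein with Bile acid receptor (Homo sapiens) as the target (on this read-out lower numbers stand for an effect already at smaller amounts and higher numbers for an effect only at larger amounts of compound), compound 1 `COC(=O)/C=C/c1cccc(N(Cc2ccc(/C=C/c3ccccc3F)cc2)C(=O)C2CCCCC2)c1` gives 64 nM, the lowest of the three numbers. Compound 2 `COC(=O)/C=C/c1cccc(N(Cc2ccc(/C=C/c3ccccc3F)cc2)C(=O)NC(C)C)c1` gives 431 nM in this assay, and the step of a 6.7-fold higher number from compound 1 to compound 2 (0.83 log units; beyond the scatter) is beyond the scatter. Compound 3 `COC(=O)/C=C/c1cccc(N(Cc2ccc(/C=C/c3c(C)cc(C)cc3C)cc2)C(=O)NC(C)C)c1` gives 431 nM in this assay, so the step of no change at the digits printed from compound 2 to compound 3 (within the scatter) lies within the scatter.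

Compound 4 `COC(=O)/C=C/c1cccc(N(Cc2ccc(/C=C/c3ccccn3)cc2)C(=O)C2CCCCC2)c1` is not yet measured. It is compound 1 with one change: pyridin-2-yl in place of 2-fluorophenyl on a double-bonded chain carbon bound to a double-bonded chain carbon. For the measured compounds named here, of the two measured steps, only the one from compound 2 to compound 3 touches the same place, and there a far larger replacement of the 2-fluorophenyl left the number unchanged within the scatter. The step from compound 1 to compound 2 concerns the carbonyl side and does not bear on this change. On that basis the step from compound 1 to compound 4 in this assay is expected to be small, most likely within the scatter, with no clear direction; the estimated step is a 1.4-fold higher number from compound 1 to compound 4 (0.15 log units; within the scatter). Compound 4 is therefore expected to give about 90 nM in this assay, within a range of 35 nM to 300 nM.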

Compound 4, half-maximal effective concentration: 309 nM
Compound 4: the middle estimate sits 3.4-fold (0.54 log units) below what was measured, and the stated range ends below it.
By their numbers in this assay, from the lowest: compound 1; then compounds 4, 2 and 3 (each within the scatter of the next).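

In this assay, the swap to pyridin-2-yl gives a 4.8-fold higher number from compound 1 to compound 4 (0.68 log units; beyond the scatter), so the group carried on a double-bonded chain carbon bound to a double-bonded chain carbon can shift the read-out beyond the scatter when the carbonyl bears cyclohexyl. Among the compounds shown here, the only earlier change at this place gave no change at the digits printed from compound 2 to compound 3 (within the scatter), but that pair carries isopropylamino on the carbonyl, and its replacement group differs from pyridin-2-yl; the two results therefore show that not every replacement of 2-fluorophenyl at this place leaves the number unchanged, though they do not show whether the carbonyl group influences the outcome. The change removes a fluorine and brings a ring nitrogen, with one hydrogen-bond acceptor entering where the leaving group has none, but no measurement is available here that explains the rise in the number.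

The compounds shown leave open whether the step follows from losing the fluorine or from gaining the ring nitrogen, a question that a plain phenyl group on the same cyclohexyl compound would help to separate. They also leave open whether pyridin-2-yl would produce a step of similar size on compound 2, with isopropylamino on the carbonyl.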